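Swapping Hydroxy for Chloro on a Shared Core

The compounds below may be only part of what the source reports. "The series", "measured", "known", "first", "only" and "open" are said of these compounds alone.

Of the compounds shown here, two built on one shared core have been tested in a functional assay on cells (Leukemia cell, Homo sapiens) for cytotoxicity, with a stated time of 48 h; on this read-out higher numbers stand for weaker inhibition of growth and lower numbers for stronger inhibition of growth. Compound 1 `COc1cc2c(/C=C3/C(=O)Nc4ccc(O)cc43)c(Cl)n(Cc3cc(OC)c(OC)c(OC)c3)c2cc1C` gives 18600 nM, and compound 2 `O=C1Nc2ccccc2/C1=C\c1c(Cl)n(Cc2ccccc2)c2ccccc12` gives 21400 nM. On the numbers shown, compound 1 stands at the lower of the two values, but its difference from compound 2 lies within the scatter of the method, so no order between them can be claimed.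

Compound 3 `COc1cc2c(/C=C3/C(=O)Nc4ccc(Cl)cc43)c(Cl)n(Cc3cc(OC)c(OC)c(OC)c3)c2cc1C` is compound 1 with a single exchange: chloro in place of hydroxy on an aromatic carbon. Within the data shown here, no measured pair shows what this exchange does on the shared core, so the expectation rests on the two numbers alone. The expected step of a 1.2-fold lower number from compound 1 to compound 3 (0.09 log units; within the scatter) is taken to stay within the scatter, with no clear direction. Compound 3 is therefore expected to give 15000 nM, with a likely range from 5000 nM to 45000 nM.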

Compound 3, concentration for total growth inhibition: 4790 nM
Beside the measured number, compound 3's estimate is 3.1-fold (0.50 log units) above it; the measured number lies below the stated range.
By their numbers in this assay, from the lowest: compound 3; then compounds 1 and 2 (each within the scatter of the next).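

In this assay, this position on the shared core is not a silent one: chloro in place of hydroxy on an aromatic carbon gives a 3.9-fold lower number from compound 1 to compound 3 (0.59 log units; beyond the scatter), a modest step but one that clears the scatter. Compound 1 and compound 2 differ in more than one place, so they could not show what a single group does here, whereas this pair isolates one exchange, in which the hydrogen-bond donor counted on hydroxy is absent from chloro. No measurement at hand gives a reason for this step.

On these data alone, only hydroxy and chloro are seen at this position, so it remains open whether fluoro, methoxy or an amine there would give a lower or a higher number. As far as these compounds go, whether the same exchange would give a similar step on a different core also remains open.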